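Methyl for Hydrogen, Once Again, on a Chlorinated Chain

The compounds below may be only part of what the source reports. "The series", "measured", "known", "first", "only" and "open" are said of these compounds alone.

Compound 1 `CC(=O)Nc1ccc(C2=NNC(=O)CC2)cc1` and compound 2 `CCC(=O)Nc1ccc(C2=NNC(=O)CC2)cc1` share a core. In a functional assay for inhibition, with Homo sapiens as the target (a higher number here means that more compound is needed for the effect, a lower number that less compound is needed), compound 1 gives 1 ug/mL, and compound 2 gives 0.64 ug/mL. The structural change between them is methyl in place of hydrogen on a saturated chain carbon bound to a carbonyl carbon, and the step it made is a 1.6-fold lower number from compound 1 to compound 2 (0.19 log units; within the scatter). Compound 3 `CC1CC(c2ccc(NC(=O)CCl)cc2)=NNC1=O` rests on a different core; how its core differs from that of compound 1 is not broken down here. In this assay compound 3 gives 21.9 ug/mL, the highest of the three numbers and beyond the scatter from both compound 1 and compound 2. Compound 4 `CC(Cl)C(=O)Nc1ccc(C2=NNC(=O)C(C)C2)cc1` has not yet been measured. It differs from compound 3 by methyl in place of hydrogen on a saturated chain carbon bound to a carbonyl carbon and a chlorine atom. This is the same kind of change as from compound 1 to compound 2, but the place is not identical: in compound 3 the saturated chain carbon is bound to a carbonyl carbon and a chlorine atom, whereas in compound 1 it is bound to a carbonyl carbon alone. A step of similar size is expected here, a 1.5-fold lower number from compound 3 to compound 4 (0.16 log units; within the scatter), because a 1.6-fold lower number from compound 1 to compound 2 (0.19 log units; within the scatter) stayed within the scatter. Compound 4 is therefore estimated to give 15 ug/mL in this assay, within a range from 5 ug/mL to 45 ug/mL.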

Compound 4, half-maximal effective concentration: 32.9 ug/mL
Compound 4: middle estimate off by 2.2-fold (0.34 log units), on the low side; the range from low to high includes it.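

In this assay, methyl in place of hydrogen on the chlorinated chain gives a 1.5-fold higher number from compound 3 to compound 4 (0.18 log units; within the scatter), so here, as on the unchlorinated chain, the change does not move the number beyond the scatter. Set side by side, the two steps cannot be told apart: the same change on two cores in this assay, a 1.6-fold lower number (0.19 log units; within the scatter) from compound 1 to compound 2 and a 1.5-fold higher number (0.18 log units; within the scatter) from compound 3 to compound 4, 2.3-fold (0.37 log units) apart, within the scatter of two such steps This shows that the change carried over from the core of compound 1 to the core of compound 3 without a step beyond the scatter, but it rests on only two pairs and does not show that the change has a real effect in either direction on either core, or that it would stay this small on any other core.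

The compounds shown leave open whether an ethyl group, a longer chain, an amine or a carboxylic acid in place of that hydrogen would give a step beyond the scatter. They also leave open how much of the small gap between the two steps belongs to the core and how much to the chlorine atom.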